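The source may report more compounds than this note shows. Statements on the series, on what has been measured and on what is new or still open speak of the compounds shown alone.

Values in a functional assay with Homo sapiens as the target; a higher number here means a weaker inhibitor, a lower number a stronger inhibitor:
- compound 1 `CC(C)[C@H](NC(=O)COc1cccc2ccccc12)C(=O)N[C@@H](CC(=O)O)C(=O)COc1ccc(F)c(F)c1F`: 20600 nM
- compound 2 `CC(C)[C@H](NC(=O)COc1cccc2ccccc12)C(=O)N[C@@H](CC(=O)O)C(=O)COc1c(F)c(F)cc(F)c1F`: 6250 nM
- compound 3 `CC(C)[C@H](NC(=O)COc1cccc2ccccc12)C(=O)N[C@@H](CC(=O)O)C(=O)COc1c(F)c(F)c(F)c(F)c1F`: 8890 nM

Compound 3 cannot be separated from its nearest neighbour: a 1.4-fold higher number from compound 2 to compound 3 (0.15 log units; within the scatter), within the scatter. The distance to the remaining value is larger: a 2.3-fold lower number from compound 1 to compound 3 (0.36 log units; beyond the scatter), beyond the scatter.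

Compound 4 `CC(C)[C@H](NC(=O)COc1cccc2ccccc12)C(=O)N[C@@H](CC(=O)O)C(=O)COc1c(F)c(F)c(-c2c(F)c(F)c(F)c(F)c2F)c(F)c1F` has 2,3,4,5,6-pentafluorophenyl in place of fluoro on an aromatic carbon, para to a large group: 2,3,4,5,6-pentafluorophenyl in place of fluoro on an aromatic carbon. Among the measured compounds shown here, no measured step adds a second aromatic ring, so the evidence is indirect. The closest change, fluoro in place of hydrogen on an aromatic carbon, gave a 1.4-fold higher number from compound 2 to compound 3 (0.15 log units; within the scatter). Rearranging the fluoro pattern gave at most a modest shift, as in a 3.3-fold lower number from compound 1 to compound 2 (0.52 log units; beyond the scatter). These steps give no firm direction, so no shift beyond the scatter is expected in this assay, though the size of the new group calls for a wide range.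

The estimated change is a 1.1-fold higher number from compound 3 to compound 4 (0.05 log units; within the scatter). Compound 4 is expected at 10000 nM, with an estimated range of 3000 nM to 35000 nM.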

Compound 4, half-maximal inhibitory concentration: 40000 nM
Compound 4: the middle estimate sits 4.0-fold (0.60 log units) below what was measured; measured number above the stated range.
By their numbers in this assay, from the lowest: compounds 2 and 3 (each within the scatter of the next); then compounds 1 and 4 (each within the scatter of the next).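

In this assay, the aromatic carbon para to a large group proves sensitive to substitution, which the small swap of hydrogen for fluoro could not show: a 1.4-fold higher number from compound 2 to compound 3 (0.15 log units; within the scatter). Placing 2,3,4,5,6-pentafluorophenyl there gives the first step at this carbon that lies beyond the scatter, and it points towards weaker inhibition, with a 4.5-fold higher number from compound 3 to compound 4 (0.65 log units; beyond the scatter) and, against hydrogen at the same carbon, a 6.4-fold higher number from compound 2 to compound 4 (0.81 log units; beyond the scatter). No measurement at hand accounts for this shift.

The compounds shown leave open whether the shift belongs to the added ring itself or to the fluoro groups it carries, and how a phenyl without fluoro, a methyl group or an amine at this carbon would read. They also leave open whether the same shift would hold with a different group in place of the carboxylic acid of the shared core.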